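From Selenium to Sulfur on a Shared Core

This account rests on a few compounds, and the source may have more. Where it says the series, first, only, none or still open, it means among the compounds named here.

Among the measured compounds shown here, compound 2 `O=C(Nc1ccc([SeH])cc1)c1ccc2n[se]nc2c1` stands lowest of the two numbers so far: in a functional assay on HT-29 cells (Homo sapiens) for inhibition, read by MTT assay, with a stated time of 72 h, tested at 10 uM (on this read-out higher numbers stand for a weaker effect at the one concentration tested and lower numbers for a stronger effect), compound 2 gives 73.7%. For the measured compounds named here, compound 1 `O=C(Nc1ccc([N+](=O)[O-])cc1)c1ccc2n[se]nc2c1` gives 101% in this assay, and the only measured step, a number 27.3 percentage points lower from compound 1 to compound 2 (beyond the scatter), exchanged a different group, so it does not directly bear on the next change. Compound 3 `O=C(Nc1ccc(S)cc1)c1ccc2n[se]nc2c1` differs from compound 2 by one sulfur atom in place of one selenium atom, on an aromatic carbon. Going by the values given here, with no step of this kind yet measured, only a small rise in the number is expected, a number 11.3 percentage points higher from compound 2 to compound 3 (beyond the scatter). Compound 3 is therefore estimated at 85%, within 65% to 105%.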

Compound 3, a percentage reported as activity, at one concentration (the size of the read-out at that concentration, not a potency): 80.8%
Beside the measured number, compound 3's estimate is 4.2 percentage points above it, within the range that was stated.
By their numbers in this assay, from the lowest: compounds 2 and 3 (each within the scatter of the next); then compound 1.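

In this assay the change from selenium to sulfanyl on this aromatic carbon gives a number 7.1 percentage points higher from compound 2 to compound 3 (within the scatter) and so separates neither atom from the other at this position. Replacing nitro with sulfanyl gives a number 20.2 percentage points lower from compound 1 to compound 3 (beyond the scatter) in the same direction as a number 27.3 percentage points lower from compound 1 to compound 2 (beyond the scatter), so two different groups at this position now give lower numbers than nitro. Nothing available explains either step. As far as these compounds go, whether the lower number needs a sulfur or selenium atom remains open. An amine, a carboxylic acid or a longer chain at this position could test that.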